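Amino in Place of Nitro at the Cytotoxicity Limit

The source may hold more compounds than are shown below. What is called first, only, known or untested is meant among the compounds shown, and "the series" means these compounds.

In an ADME assay on HEp-2 cells (Homo sapiens) for cytotoxicity, read by MTT assay, with a stated time of 72 h (on this read-out lower numbers stand for stronger inhibition and higher numbers for weaker inhibition), compound 1 (`COc1ccc(C2=C(c3cc(OC)c(OC)c(OC)c3)CC(O)C2=O)cc1[N+](=O)[O-]`) gives > 100 ug/mL, which is a limit and not a number. Compound 2 (`COc1ccc(C2=C(c3cc(OC)c(OC)c(OC)c3)CC(O[SiH2]C(C)(C)C)C2=O)cc1[N+](=O)[O-]`) gives > 100 ug/mL, also a limit. Among the measured compounds shown here, the only measured step is a step that the two limits leave unreadable from compound 1 to compound 2, and it lies elsewhere on the molecule; the evidence amounts to the limit of > 100 ug/mL in this assay, at which 2 of the 2 values shown sit. Compound 3 (`COc1ccc(C2=C(c3cc(OC)c(OC)c(OC)c3)CC(O)C2=O)cc1N`) differs from compound 1 by amino in place of nitro on an aromatic carbon, with amino in place of nitro on an aromatic carbon, ortho to a methoxy group. For the measured compounds named here, no measured step gives a size for this change. Only a move toward stronger inhibition in this assay could appear as a number, so that direction is expected, with an estimated at least 2.5-fold lower number from compound 1 to compound 3 (0.39 log units; beyond the scatter). Compound 3 is expected at 40 ug/mL, within 2 ug/mL to 200 ug/mL.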

Compound 3, half-maximal inhibitory concentration: 16 ug/mL
Compound 3: middle estimate off by 2.5-fold (0.40 log units), on the high side, within the range that was stated.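

Among the compounds shown here, on the aromatic carbon ortho to a methoxy group, amino in place of nitro gives the first readable step in this assay: an at least 6.2-fold lower number from compound 1 to compound 3 (0.79 log units; beyond the scatter). The step on the oxygen cannot be read, so this aromatic position is the only place shown where a change can be sized. Compound 3 alone gives a number rather than a limit: the limit of > 100 ug/mL in this assay, at which 2 of the 3 values shown sit.

The compounds shown leave open how a hydroxyl, an acetamide or a dimethylamino group would read at this position. They also leave open whether amino has the same effect with the oxygen substituent of compound 2 in place.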